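The source may hold more compounds than are shown below. What is called first, only, known or untested is meant among the compounds shown, and "the series" means these compounds.

Series notes, measured in a functional assay on KB cells (Homo sapiens) for inhibition, read by MTT assay, with a stated time of 24 h, tested at 1 ug/mL; a lower number here means less inhibition of growth, a higher number more inhibition of growth at the concentration tested:

- compound 1 `O=C(CCCCC1CCSS1)Nc1ccc(Cl)cn1`: 0.76%
- compound 2 `O=C(CCCCC(S)CCS)Nc1ccc(F)cc1`: 8.84%

Among the measured compounds shown here, compound 2, at 8.84%, is one of only two measured compounds, and its value lies within the usual scatter of the value for compound 1, so the two cannot be ranked. For the measured compounds named here, no step between measured compounds that differ in one place is available, which leaves the effect of a single change unmeasured.

The next compound is compound 3 `O=C(CCCCC(S)CCS)Nc1ccc([N+](=O)[O-])cc1`, with nitro in place of fluoro on an aromatic carbon, para to a large group: nitro in place of fluoro on an aromatic carbon. The measured values give no sign of a large shift in this assay. Going by the values given here, the expectation is anchored on compound 2 at 8.84%, with wide margins because no single-change step has been measured. The expected step is none beyond the scatter: a number 0.2 percentage points higher from compound 2 to compound 3 (within the scatter). The upper margin is wider, since growth inhibition cannot be expected to fall far under these values. For compound 3 the estimated value is 9%, with an expected range from 0% to 24%.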

Compound 3, percent growth inhibition at one concentration: 0.93%
Compound 3: middle estimate off by 8.1 percentage points, on the high side, and the stated range covers the measured number.
By their numbers in this assay, from the lowest: compounds 1, 3 and 2 (each within the scatter of the next).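

a number 7.9 percentage points lower from compound 2 to compound 3 (within the scatter) in this assay; this is the first single-change step in the series, and it shows that nitro in place of fluoro, on an aromatic carbon para to a large group, gives no difference that can be read beyond the scatter. With compound 2 at 8.84% and compound 3 at 0.93%, both numbers lie close to zero at the one concentration tested, so this pair gives no sign that the choice between these two groups at this position matters for growth inhibition in this assay. No measurement on hand bears on the reason for this result.

Open, from the compounds shown here alone, is whether any group at this position can move the number beyond the scatter, for instance an amine or a carboxylic acid in place of fluoro on the same aromatic ring. Also open, going by these compounds, is what a single change elsewhere would do, such as a longer chain between the amide carbonyl and the sulfur-bearing end, since one step at one position says nothing about the rest of the shared core.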